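This account rests on a few compounds, and the source may have more. Where it says the series, first, only, none or still open, it means among the compounds named here.

Measured so far in a functional assay on HeLa cells (Homo sapiens) for antiproliferative activity, read by CCK-8 assay, with a stated time of 72 h; a higher number here means a weaker inhibitor, a lower number a stronger inhibitor:
compound 1 `CCSc1ccc(-c2cncnc2-c2cc(OC)c(OC)c(OC)c2)cc1` gives 370 nM
compound 2 `COc1cc(-c2ncncc2-c2ccc(Br)cc2)cc(OC)c1OC` gives 500 nM

Going by the values given here, compound 2 stands within the scatter of compound 1, the only other measured compound. Compound 3 `COc1cc(-c2ncncc2-c2ccc3cc[nH]c3c2)cc(OC)c1OC` carries 1H-indol-6-yl in place of 4-bromophenyl on an aromatic carbon. Among the compounds with values here, the one measured step, bromo in place of ethylsulfanyl, is a 1.4-fold higher number from compound 1 to compound 2 (0.13 log units; within the scatter) and replaced no whole ring, so it is only a loose guide. No step beyond the scatter is expected, though the range stays wide. Expected is a 1.7-fold lower number from compound 2 to compound 3 (0.22 log units; within the scatter) at the centre of the estimate. Compound 3 is estimated at 300 nM within an expected range from 50 nM to 1500 nM overall.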

Compound 3, half-maximal inhibitory concentration: 770 nM
For compound 3 the middle estimate is 2.6-fold (0.41 log units) below the measured one; the range from low to high includes it.
By their numbers in this assay, from the lowest: compounds 1, 2 and 3 (each within the scatter of the next, the first and the last beyond it).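

In this assay, a whole two-ring group can stand at this position: the step of a 1.5-fold higher number from compound 2 to compound 3 (0.19 log units; within the scatter) shows 1H-indol-6-yl replacing 4-bromophenyl without leaving the scatter. Set against 4-(ethylsulfanyl)phenyl, the same group gives a 2.1-fold higher number from compound 1 to compound 3 (0.32 log units; beyond the scatter) and so yields the first modest step at this position. No evidence at hand bears on what lies behind these steps. Going by these compounds, what remains open is whether the hydrogen-bond donor of 1H-indol-6-yl plays any part in these numbers. On these data alone, it is also open how an amine, a carboxylic acid or a longer chain on the phenyl ring would compare.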